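The source may hold more compounds than are shown below. What is called first, only, known or untested is meant among the compounds shown, and "the series" means these compounds.

Series notes, antiproliferative set

Compound 1 `COc1cc2ncnc(N3CCc4ccccc43)c2cc1NC(=O)/C=C/CN1CCCC1` is the reference point. In a functional assay on A549 cells (Homo sapiens) for antiproliferative activity, read by MTT assay, with a stated time of 72 h (on this read-out lower numbers stand for stronger inhibition and higher numbers for weaker inhibition), compound 1 gives 1210 nM. Two single changes have been made from it. Compound 2 `COc1cc2ncnc(N3CCc4ccccc43)c2cc1NC(=O)/C=C/CN1CCCCC1` carries piperidin-1-yl in place of pyrrolidin-1-yl on a saturated chain carbon bound to a double-bonded chain carbon; in this assay compound 2 gives 2540 nM, a step of a 2.1-fold higher number from compound 1 to compound 2 (0.32 log units; beyond the scatter). Compound 3 `COc1cc2ncnc(N3CCCc4ccccc43)c2cc1NC(=O)/C=C/CN1CCCC1` differs from compound 1 in the core, by 1,2,3,4-tetrahydroquinolin-1-yl in place of 2,3-dihydro-1H-indol-1-yl on an aromatic carbon; in this assay compound 3 gives 2230 nM, a step of a 1.8-fold higher number from compound 1 to compound 3 (0.27 log units; within the scatter). Compound 2 and compound 3 lie close to one another, and the cores of compound 1 and compound 3 are otherwise the same.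

Compound 4 `COc1cc2ncnc(N3CCCc4ccccc43)c2cc1NC(=O)/C=C/CN1CCCCC1` has not yet been measured in this assay. It is related to compound 3 by piperidin-1-yl in place of pyrrolidin-1-yl on a saturated chain carbon bound to a double-bonded chain carbon, the same change, at the same place, that separates compound 1 from compound 2. Within the data shown here, that change occurs twice in the set, and the one measured instance of it is the step of a 2.1-fold higher number from compound 1 to compound 2 (0.32 log units; beyond the scatter), a modest weakening. Among the measured compounds shown here, with only one measured instance, nothing can be said about whether the core of compound 3 alters the size of that step, so the estimate carries it over unchanged.

Compound 4 is therefore expected to read higher than compound 3, with the expected step being a 2.1-fold higher number from compound 3 to compound 4 (0.32 log units; beyond the scatter). In this assay compound 4 is estimated at 4700 nM. For the measured compounds named here, the estimate for compound 4 is expected to fall between 2500 nM and 9000 nM, allowing for the scatter of the assay and the single precedent.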

Compound 4, half-maximal inhibitory concentration: 2880 nM
The estimate for compound 4 lay 1.6-fold (0.21 log units) above the measured number; the measured number falls inside the stated range.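

Working from the shared core with piperidin-1-yl in place, the exchange of 2,3-dihydro-1H-indol-1-yl for 1,2,3,4-tetrahydroquinolin-1-yl in this assay gives a 1.1-fold higher number from compound 2 to compound 4 (0.05 log units; within the scatter), and this cannot be told apart from its counterpart with pyrrolidin-1-yl in place: the same change on two cores in this assay, a 1.8-fold higher number (0.27 log units; within the scatter) from compound 1 to compound 3 and a 1.1-fold higher number (0.05 log units; within the scatter) from compound 2 to compound 4, 1.6-fold (0.21 log units) apart, within the scatter of two such steps

The exchange of pyrrolidin-1-yl for piperidin-1-yl, carried to the core of compound 3, gives a 1.3-fold higher number from compound 3 to compound 4 (0.11 log units; within the scatter), and the two instances of this change likewise cannot be told apart: the same change on two cores in this assay, a 2.1-fold higher number (0.32 log units; beyond the scatter) from compound 1 to compound 2 and a 1.3-fold higher number (0.11 log units; within the scatter) from compound 3 to compound 4, 1.6-fold (0.21 log units) apart, within the scatter of two such steps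

This shows that the four compounds give no sign of either change depending on the other, but it does not show that the steps are equal in size, since each change rests on only two instances from a single set of four compounds, and the piperidin-1-yl step lies beyond the scatter on one core and within it on the other.

The compounds shown leave open how a morpholin-4-yl or a dimethylamino group would read on the same saturated chain carbon. They also leave open whether the piperidin-1-yl step would hold with an ethoxy group in place of the methoxy group on the shared core.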